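This account rests on a few compounds, and the source may have more. Where it says the series, first, only, none or still open, it means among the compounds named here.

In an ADME assay on THP-1 cells (Homo sapiens) for cytotoxicity, read by MTT assay, with a stated time of 72 h (on this read-out higher numbers stand for lower toxicity in this test and lower numbers for higher toxicity in this test), compound 3 `O[C@@H]1Cc2ccccc2N[C@H](c2c(Cl)cccc2Cl)C1` reaches only a limit of the assay, > 300000 nM. Compound 1 `O[C@@H]1Cc2ccccc2N[C@H](c2ccccc2Cl)C1` likewise sits at a limit, > 300000 nM. Compound 2 `O[C@@H]1Cc2ccccc2N[C@H](c2ccccc2F)C1` also stops at a limit, > 300000 nM. The two steps a step that the two limits leave unreadable from compound 1 to compound 2 and a step that the two limits leave unreadable from compound 1 to compound 3 therefore carry no readable size because of the limit of > 300000 nM in this assay, at which 3 of the 3 values shown sit. Compound 4 `O[C@@H]1Cc2ccccc2N[C@H](c2c(F)cccc2Cl)C1` differs from compound 3 by fluoro in place of chloro on an aromatic carbon. Both measured steps bear on this change, one exchanging fluoro for chloro and one adding chloro, yet neither shows a size, so no step beyond the scatter is expected, and the change is estimated as a step that the limit leaves unreadable from compound 3 to compound 4. Compound 4 is consequently expected to give about 400000 nM, in a range from 200000 nM to 1000000 nM, most probably again reported only as a limit.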

Compound 4, half-maximal cytotoxic concentration: > 300000 nM
Compound 4 gave a limit, no number; the forecaster's own chance of this, stated with the estimate: 85%; the middle value lies beyond the limit too.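

Compound 4 joins compound 1, compound 2 and compound 3 at a limit, so no step among these compounds can be read: the limit of > 300000 nM in this assay, at which 4 of the 4 values shown sit.

The compounds shown leave open whether any of these aromatic substituent changes shifts the read-out at all.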